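This account rests on a few compounds, and the source may have more. Where it says the series, first, only, none or still open, it means among the compounds named here.

Measured so far in a functional assay on HL-60 cells (Homo sapiens) for antiproliferative activity, with a stated time of 24 h; on this read-out higher numbers stand for weaker inhibition and lower numbers for stronger inhibition:
Compound 1, `NC(=O)c1c(NC(=O)c2ccccc2Cl)sc2c1CCN(C(=S)Nc1ccccc1Br)C2`, gives 9090 nM.
Compound 2, `NC(=O)c1c(NC(=O)c2ccccc2Br)sc2c1CCN(C(=S)Nc1ccccc1Br)C2`, gives 17600 nM.
Compound 3, `NC(=O)c1c(NC(=O)c2ccccc2C(F)(F)F)sc2c1CCN(C(=S)Nc1ccccc1F)C2`, gives 23500 nM.

Compound 3 gives the highest of these three numbers; its gap to compound 2 is within the scatter, its gap to compound 1 beyond it. Compound 4, `NC(=O)c1c(NC(=O)c2ccccc2C(F)(F)F)sc2c1CCN(C(=S)Nc1ccccc1Br)C2`, differs from compound 3 by bromo in place of fluoro on an aromatic carbon. Among the compounds with values here, the only measured halogen swap, a 1.9-fold higher number from compound 1 to compound 2 (0.29 log units; within the scatter), sits on the other aromatic ring and stayed within the scatter; no step on this ring has been measured. A bromo on this ring is already present in compound 1 and compound 2. So in this assay compound 4 is expected to move little, by about a 1.3-fold lower number from compound 3 to compound 4 (0.12 log units; within the scatter), giving an estimated 18000 nM (range 8000 nM to 45000 nM).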

Compound 4, half-maximal inhibitory concentration: 25500 nM
Compound 4: middle estimate off by 1.4-fold (0.15 log units), on the low side, within the range that was stated.
By their numbers in this assay, from the lowest: compounds 1, 2, 3 and 4 (each within the scatter of the next, the first and the last beyond it).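

On this ring, the change from 2-fluorophenyl to 2-bromophenyl leaves this assay within the scatter (a 1.1-fold higher number from compound 3 to compound 4 (0.04 log units; within the scatter)), so these two halogens cannot be told apart here. On the other aromatic ring, trifluoromethyl in place of bromo also stays within the scatter (a 1.4-fold higher number from compound 2 to compound 4 (0.16 log units; within the scatter)), while trifluoromethyl in place of chloro goes modestly beyond it (a 2.8-fold higher number from compound 1 to compound 4 (0.45 log units; beyond the scatter)). No evidence is available to explain these numbers. From the compounds shown here alone, whether a methoxy group, an amine or a carboxylic acid on this ring would shift the number remains open, as does the effect of a plain hydrogen there.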